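What a propyl group may do to compound 3

The source may report more compounds than this note shows. Statements on the series, on what has been measured and on what is new or still open speak of the compounds shown alone.

compound 1 `CCCNCCCNCCCNCCC` gives 60000 nM
compound 2 `CCCNCCCNCCCCN` gives 28000 nM
compound 3 `CCCNCCCCNCCCN` gives 55000 nM

Compound 3 stands at 55000 nM in a functional assay on L1210 cells (Mus musculus) for inhibition, with a stated time of 96 h (a lower number here means a stronger inhibitor, a higher number a weaker inhibitor), and lies within the usual scatter of both compound 1 and compound 2, although those two differ from each other by more than the scatter.

For the measured compounds named here, compound 4 `CCCNCCCCNCCCNCCC` has no measurement yet. It differs from compound 3 as follows: propyl in place of hydrogen on an amine nitrogen and the change is propyl in place of hydrogen on an amine nitrogen.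

Going by the values given here, only one measured step bears on this. It runs a 2.1-fold lower number from compound 1 to compound 2 (0.33 log units; beyond the scatter) and puts aminomethyl in place of propylamino. That step takes away a propyl-bearing amine, while compound 4 gains propyl, so read backwards it hints at a somewhat higher number in this assay for compound 4. Among the compounds with values here, the hint is weak, since it is a single modest step and no measured pair shows propyl added with the rest of the chain unchanged.

A small rise or no change beyond the scatter is therefore expected. The estimated change is a 1.1-fold higher number from compound 3 to compound 4 (0.04 log units; within the scatter) and it carries wide uncertainty. The expected value for compound 4 is 60000 nM with an estimated range from 20000 nM to 150000 nM around it.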

Compound 4, half-maximal inhibitory concentration: 33000 nM
Estimate against measurement, compound 4: 1.8-fold (0.26 log units) above; measured number inside the range.
By their numbers in this assay, from the lowest: compounds 2, 4, 3 and 1 (each within the scatter of the next, the first and the last beyond it).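

In this assay, for the compounds shown here, propyl in place of hydrogen on an amine nitrogen gives a 1.7-fold lower number from compound 3 to compound 4 (0.22 log units; within the scatter) and so, for the first time, the group is seen added with the rest of the chain unchanged. The same change made on compound 2 gives a 1.2-fold higher number from compound 2 to compound 4 (0.07 log units; within the scatter) so in both pairs the added propyl leaves a number that cannot be told apart from that of the compound without it, and the earlier hint of a rise with propyl finds no support here. Likewise, the remaining new pair gives a 1.8-fold lower number from compound 1 to compound 4 (0.26 log units; within the scatter) which means that this swap also stays inside the ordinary spread of repeated measurements.

As far as these compounds go, whether a longer chain such as butyl, or a benzyl group, on this amine nitrogen would move the number beyond the scatter remains open. Nothing available explains why these numbers lie so close together.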